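Swapping an aromatic side group for a plain chain

The source may report more compounds than this note shows. Statements on the series, on what has been measured and on what is new or still open speak of the compounds shown alone.

Of the compounds shown here, three of one shared core have been measured in a functional assay with Mus musculus as the target; on this read-out lower numbers stand for an effect already at smaller amounts and higher numbers for an effect only at larger amounts of compound. Compound 1 `COc1ccc(Cn2c(=O)n(C3OC(CO)[C@@H](O)[C@H]3O)c3nc(N)nc(O)c32)cc1` gives the lowest of the three numbers in this assay, at 2 uM. Compound 2 `C=CCn1c(=S)n(COCCO)c2nc(N)nc(O)c21` comes nearest, with 13 uM in this assay, a gap beyond the usual scatter, and compound 3 `CCCn1c(=O)n(C2C=CC(CO)O2)c2nc(N)nc(O)c21` lies furthest, at 52 uM in this assay. Compounds 2 and 3 each differ from compound 1 in several places at once, so none of these gaps can be tied to a single structural change.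

Compound 4 `CCCCCCn1c(=O)n(C2OC(CO)[C@@H](O)[C@H]2O)c2nc(N)nc(O)c21` has not yet been measured. It is compound 1 with one alteration: pentyl in place of 4-methoxyphenyl on a saturated chain carbon bound to an aromatic nitrogen. Cut one bond further out, the same change reads 4-methoxybenzyl to hexyl, so the aromatic ring on the chain carbon bound to the aromatic nitrogen is gone and a longer plain chain takes its place.

Nothing measured isolates this change. Compound 3, which also carries a simple alkyl chain at that nitrogen, gives a much higher number than compound 1, yet it differs elsewhere too. On that thin basis compound 4 is expected to land somewhat above compound 1, a step of a 5.0-fold higher number from compound 1 to compound 4 (0.70 log units; beyond the scatter) beyond the scatter. The estimate for compound 4 in this assay is 10 uM, within a range from 3 uM to 40 uM.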

Compound 4, concentration for half-maximal effect: 600 uM
Compound 4: the middle estimate sits 60-fold (1.78 log units) below what was measured, and the stated range ends below it.
By their numbers in this assay, from the lowest: compound 1; then compound 2; then compound 3; then compound 4.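

Among the compounds shown here, compound 1 and compound 4 differ in one place only, so this pair gives the first clean reading of the group on the saturated chain carbon bound to an aromatic nitrogen. In this assay, pentyl in place of 4-methoxyphenyl gives a 300-fold higher number from compound 1 to compound 4 (2.48 log units; beyond the scatter), a large step beyond the scatter, which shows that this one group can by itself strongly shift the amount of compound needed for an effect while the rest of the molecule stays the same. Nothing available explains why the step is so large.

The change removes the aromatic ring and the methoxy oxygen together, and adds a plain chain in their place, so the pair cannot show which of these matters most. A plain benzyl group at this place would keep the ring without the methoxy group, while a shorter chain such as propyl or butyl, on the same sugar-bearing core of compound 1, would show whether the length of a plain chain changes the number at all.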